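The source may report more compounds than this note shows. Statements on the series, on what has been measured and on what is new or still open speak of the compounds shown alone.

In a functional assay on RAW264.7 cells (Mus musculus) for inhibition, with stated times of 1 h and 24 h; on this read-out lower numbers stand for stronger inhibition and higher numbers for weaker inhibition:
- compound 1 `COc1cc(NC(=O)c2cccc(-c3cc(=O)c4c(OC)c(OC)c(OC)cc4o3)c2)cc(OC)c1OC` gives 3400 nM
- compound 2 `COc1ccccc1NC(=O)c1cccc(-c2cc(=O)c3c(O)c(OC)c(OC)cc3o2)c1` gives 2380 nM
- compound 3 `COc1cccc(NC(=O)c2cccc(-c3cc(=O)c4c(O)c(OC)c(OC)cc4o3)c2)c1` gives "not determined" (no result reported)

Compound 3 has no number, so it cannot be placed against the other two, whose values lie within the usual scatter of each other. Compound 4 `COc1cc(NC(=O)c2cccc(-c3cc(=O)c4c(O)c(OC)c(OC)cc4o3)c2)cc(OC)c1OC` awaits measurement. The change 3,4,5-trimethoxyphenyl in place of 3-methoxyphenyl on an amide-type nitrogen puts 3,4,5-trimethoxyphenyl in place of 3-methoxyphenyl on an amide-type nitrogen. The entering group already appears, on a different core, in compound 1 at 3400 nM. The core of compound 4 appears in compound 2 at 2380 nM. In this assay, a result close to these two is therefore expected, with no step beyond the scatter in either direction. Compound 4 is estimated at 2800 nM, with an expected range of 1000 nM to 8000 nM.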

Compound 4, half-maximal inhibitory concentration: 980 nM
Compound 4: middle estimate off by 2.9-fold (0.46 log units), on the high side; measured number outside the range, below it.
By their numbers in this assay, from the lowest: compound 4; then compounds 2 and 1 (each within the scatter of the next).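

Putting 3,4,5-trimethoxyphenyl in place of 2-methoxyphenyl on the amide-type nitrogen gives a 2.4-fold lower number from compound 2 to compound 4 (0.39 log units; beyond the scatter) in this assay, so this position responds to the change of aryl group. Hydrogen in place of methyl on an oxygen on an aromatic ring gives a 3.5-fold lower number from compound 1 to compound 4 (0.54 log units; beyond the scatter), so the 3,4,5-trimethoxyphenyl amide also responds to a change in the core. Nothing available explains either step.

Compound 3 has no number, so its step to compound 4 cannot be read. From the compounds shown here alone, how an amine or a carboxylic acid on this aromatic ring would compare remains open.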